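The source may hold more compounds than are shown below. What is called first, only, known or untested is meant among the compounds shown, and "the series" means these compounds.

Compound 1 `COc1cc(O)c(C(=O)/C=C/c2cccc(N3CCN(C)CC3)c2)c(OC)c1`: 62200 nM
Compound 2 `COc1cc(OC)c(C(=O)/C=C/c2ccc(N3CCN(C(=O)OC(C)(C)C)CC3)cc2)c(O)c1CC=C(C)C`: > 100000 nM, a limit of the assay
Compound 3 `COc1cc(OC)c(C(=O)/C=C/c2ccc(OC)c(OC)c2OC)c(O)c1CC=C(C)C`: 62700 nM

In an ADME assay on MCF7-DOX cells (Homo sapiens) for cytotoxicity, read by MTT assay, with a stated time of 48 h (on this read-out higher numbers stand for weaker inhibition and lower numbers for stronger inhibition), compound 1 gives 62200 nM, which lies within the usual scatter of compound 3 at 62700 nM. Compound 4 `COc1cc(O)c(C(=O)/C=C/c2cccc(N3CCN(C(=O)OC(C)(C)C)CC3)c2)c(OC)c1` is still unmeasured. It has tert-butoxycarbonyl in place of methyl on an amine nitrogen in a ring of compound 1: tert-butoxycarbonyl in place of methyl on an amine nitrogen in a ring. Among the measured compounds shown here, no measured pair shows this change alone. Compound 2 also carries tert-butoxycarbonyl on such a nitrogen, and its > 100000 nM is a limit. A modest move towards weaker inhibition in this assay is therefore expected, and the reading may reach the limit. The expected change is a 1.4-fold higher number from compound 1 to compound 4 (0.14 log units; within the scatter). For compound 4 the estimate is 85000 nM, with an expected range of 35000 nM to 200000 nM.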

Compound 4, half-maximal inhibitory concentration: 56700 nM
Beside the measured number, compound 4's estimate is 1.5-fold (0.18 log units) above it; measured number inside the range.
By their numbers in this assay, from the lowest: compounds 4, 1 and 3 (each within the scatter of the next). At a limit, above all of these: compound 2.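

In this assay, tert-butoxycarbonyl in place of methyl on an amine nitrogen in a ring gives a 1.1-fold lower number from compound 1 to compound 4 (0.04 log units; within the scatter). Among the compounds shown here, this pair shows the change alone for the first time, and the two readings cannot be told apart, even though the entering group is much larger than methyl. Carrying tert-butoxycarbonyl on this nitrogen is thus not enough on its own to reach a limit, and compound 2 carries a limit of the assay: the limit of > 100000 nM in this assay, at which 1 of the 4 values shown sits.

Going by these compounds, whether a free amine or a longer alkyl chain on this nitrogen would also leave the reading in place stays open.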